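Swapping the fluorophenyl group of compound 3

The source may report more compounds than this note shows. Statements on the series, on what has been measured and on what is new or still open speak of the compounds shown alone.

Measured so far in a functional assay on HCT-116 cells (Homo sapiens) for antiproliferative activity, read by sulforhodamine B assay, with a stated time of 48 h (a lower number here means a stronger inhibitor, a higher number a weaker inhibitor), are these compounds:
compound 1 `COc1cc(O)c(C(=O)/C=C/c2ccc(F)cc2)c(OC)c1` gives 4400 nM
compound 2 `COc1cccc(/C=C/C(=O)c2c(O)cc(OC)cc2OC)c1` gives 3100 nM
compound 3 `COc1cc(OC)c(C(=O)/C=C/c2ccc(F)cc2)c(OCC=C(C)C)c1` gives 3200 nM

Compound 3 sits within the usual scatter of both compound 1 and compound 2, so its value sets no order among them. Compound 4 `COc1cc(/C=C/C(=O)c2c(OC)cc(OC)cc2OCC=C(C)C)cc(OC)c1` keeps the core of compound 3 but carries 3,5-dimethoxyphenyl in place of 4-fluorophenyl (3,5-dimethoxyphenyl in place of 4-fluorophenyl on a double-bonded chain carbon bound to a double-bonded chain carbon). Among the compounds with values here, the only measured step here (a 1.4-fold lower number from compound 1 to compound 3 (0.14 log units; within the scatter)) lies within the scatter and concerns a different group, so it says little directly about this swap. Compound 2, whose ring on the double-bonded chain carbon carries a methoxy group, gives 3100 nM and so offers no hint of a large shift. Nothing measured here points to a clear direction in this assay, so no step beyond the scatter is expected. The estimate is a small change (a 1.1-fold lower number from compound 3 to compound 4 (0.06 log units; within the scatter)) that stays within the scatter. Compound 4 is estimated at 2800 nM (expected range 900 nM to 8000 nM).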

Compound 4, half-maximal inhibitory concentration: 3500 nM
The estimate for compound 4 lay 1.3-fold (0.10 log units) below the measured number, within the range that was stated.
By their numbers in this assay, from the lowest: compounds 2, 3, 4 and 1 (each within the scatter of the next).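

In this assay, the swap to 3,5-dimethoxyphenyl from 4-fluorophenyl on a double-bonded chain carbon bound to a double-bonded chain carbon gives a 1.1-fold higher number from compound 3 to compound 4 (0.04 log units; within the scatter) and so stays within the scatter. This is the first direct reading at this place among the compounds shown: the entering group has more heavy atoms and adds hydrogen-bond acceptors, yet the number does not shift measurably. Nothing available explains why these two groups read alike.

On these data alone, it remains open whether a different kind of group at this place, such as a ring bearing an amine or a carboxylic acid, would give a step beyond the scatter. Also open, as far as these compounds go, is whether the same swap would read alike on the core of compound 1, which has hydrogen on the oxygen where compound 3 has 3-methylbut-2-en-1-yl.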